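Methyl to methoxy on the aryl ring across two cores

The source may report more compounds than this note shows. Statements on the series, on what has been measured and on what is new or still open speak of the compounds shown alone.

Measured in a functional assay on MCF7 cells (Homo sapiens) for antiproliferative activity, read by MTT assay, with a stated time of 72 h; a higher number here means a weaker inhibitor, a lower number a stronger inhibitor:
compound 1 `CCOC(=O)c1csc2nc(CN3CCN(Cc4ccccc4)CC3)c(-c3ccc(C)cc3)n12`: 29100 nM
compound 2 `CCOC(=O)c1csc2nc(CN3CCN(Cc4ccccc4)CC3)c(-c3ccc(OC)cc3)n12`: 17100 nM
compound 3 `Cc1ccc(-c2c(CN3CCCCC3)nc3scc(C(=O)O)n23)cc1`: 8290 nM

Among the compounds with values here, the one change made twice in the set is methoxy in place of methyl on an aromatic carbon. Between compound 1 and compound 2 it gives a 1.7-fold lower number from compound 1 to compound 2 (0.23 log units; within the scatter). The same change, at the same place, is methoxy in place of methyl on an aromatic carbon, leading to compound 4 `COc1ccc(-c2c(CN3CCCCC3)nc3scc(C(=O)O)n23)cc1`, which is not yet measured in this assay. The difference between the core of compound 1 and the core of compound 3 is not broken down here; compound 3 shows the lowest number of the three measured, beyond the scatter from both compound 1 and compound 2.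

Compound 4 is expected to sit at 5500 nM in this assay, with a step of a 1.5-fold lower number from compound 3 to compound 4 (0.18 log units; within the scatter) estimated from compound 3. This rests on the size of the earlier step, a 1.7-fold lower number from compound 1 to compound 2 (0.23 log units; within the scatter), and on the value of compound 3, 8290 nM; a range from 2500 nM to 12000 nM is expected.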

Compound 4, half-maximal inhibitory concentration: 62900 nM
Compound 4: middle estimate off by 11-fold (1.06 log units), on the low side, outside the stated range (above it).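

On the core of compound 3, 4-methylphenyl to 4-methoxyphenyl gives a 7.6-fold higher number from compound 3 to compound 4 (0.88 log units; beyond the scatter) in this assay, so the step seen on the core of compound 1 does not carry over to this core, and the two steps differ: the same change on two cores in this assay, a 1.7-fold lower number (0.23 log units; within the scatter) from compound 1 to compound 2 and a 7.6-fold higher number (0.88 log units; beyond the scatter) from compound 3 to compound 4, 13-fold (1.11 log units) apart, beyond the scatter of two such steps. Within the data shown here, this does not show which part of the core matters, as the cores of compound 1 and compound 3 differ in more than one place and no compound pair here separates those differences. With a single pair on each core, and the step on the core of compound 1 lying within the scatter, no general rule for this change in the series can be drawn.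

The compounds shown leave open how a chloro or hydroxy group at the same place on the aromatic ring would behave on either core. They also leave open whether an amide in place of the carboxylic acid of compound 3 would keep the step seen on that core.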